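Replacing the hydroxy group of compound 3

This account rests on a few compounds, and the source may have more. Where it says the series, first, only, none or still open, it means among the compounds named here.

Measured so far, all in a functional assay on COLO 205 cells (Homo sapiens) for antiproliferative activity (a higher number here means a weaker inhibitor of growth, a lower number a stronger inhibitor of growth), as follows
- compound 1 `COCCCCCCCCCCC/C=C1\CC(CO)(COC(=O)C(C)(C)C)OC1=O` gives 0.541 ug/mL
- compound 2 `CCCCCCCCC(O)CCCCCC/C=C1\CC(CO)(COC(=O)C(C)(C)C)OC1=O` gives 8.91 ug/mL
- compound 3 `CC(C)(C)C(=O)OCC1(CO)C/C(=C\CCCCCCCCCCCO)C(=O)O1` gives 2.49 ug/mL

Compound 3 holds the middle place of the three numbers. The steps that frame it are a 4.6-fold higher number from compound 1 to compound 3 (0.66 log units; beyond the scatter) and a 3.6-fold lower number from compound 2 to compound 3 (0.55 log units; beyond the scatter) in this set, while the widest gap is a 16-fold higher number from compound 1 to compound 2 (1.22 log units; beyond the scatter) in the same read-out.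

The next compound is compound 4 `CC(C)(C)C(=O)OCCCCCCCCCCCCCCC/C=C1\CC(CO)(COC(=O)C(C)(C)C)OC1=O` and its change is 4-(((tert-butyl)carbonyl)oxy)butyl in place of hydroxy on a saturated chain carbon, ten or more bonds along the chain from a double-bonded chain carbon so no free hydroxy remains on the chain. The nearest measured precedent is the pair of compound 1 and compound 3, which differ by methyl in place of hydrogen on that oxygen, a modest step of a 4.6-fold higher number from compound 1 to compound 3 (0.66 log units; beyond the scatter) in favour of the capped compound. Compound 2 and compound 3, both with a free chain hydroxy, have higher numbers than compound 1, though three compounds make a thin pattern. Among the measured compounds shown here, no measured compound carries the entering group on its chain, so the precedent is only partial.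

A modest move towards a lower number in this assay is therefore expected. The expected change is a 2.1-fold lower number from compound 3 to compound 4 (0.32 log units; beyond the scatter) and it is held loosely. For compound 4 the estimated value is 1.2 ug/mL with 0.3 ug/mL to 6 ug/mL as the expected range.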

Compound 4, concentration for 50% growth inhibition: 0.597 ug/mL
Beside the measured number, compound 4's estimate is 2.0-fold (0.30 log units) above it; the range from low to high includes it.
By their numbers in this assay, from the lowest: compounds 1 and 4 (each within the scatter of the next); then compound 3; then compound 2.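

In this assay, 4-(((tert-butyl)carbonyl)oxy)butyl in place of hydroxy gives a 4.2-fold lower number from compound 3 to compound 4 (0.62 log units; beyond the scatter) and so shows that a free hydroxy at this place on the chain is not required for growth inhibition; among compounds 1, 3 and 4, the two without a free chain hydroxy have the lower numbers. Methoxy and 4-(((tert-butyl)carbonyl)oxy)butyl at this place, which differ widely in heavy-atom count, give a 1.1-fold higher number from compound 1 to compound 4 (0.04 log units; within the scatter) and cannot be separated in this read-out, so the gain seen with the methoxy cap is not tied to that one small group. No supporting measurement is available to explain why removing the free hydroxy lowers the number.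

The compounds shown cannot say whether the shared feature is simply the absence of a hydroxy hydrogen or whether other end groups would serve as well, since only two caps are compared with the free hydroxy at this place. A terminal amine or carboxylic acid at this place, or a longer chain ending in methoxy, would test how far this tolerance extends.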